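The source may hold more compounds than are shown below. What is called first, only, known or untested is meant among the compounds shown, and "the series" means these compounds.

Working notes on the series. Compound 1 `COc1ccccc1CC1(OC)CCN(c2ccc(C(=O)NS(=O)(=O)c3ccc(N[C@H](CCN(C)C)CSc4ccccc4)c([N+](=O)[O-])c3)cc2)CC1` gives 250 nM in a functional assay (FL5.12 cells, Mus musculus) with Apoptosis regulator Bcl-2 (Homo sapiens) as the target; on this read-out lower numbers stand for an effect already at smaller amounts and higher numbers for an effect only at larger amounts of compound. Compound 2 `CN(C)CC[C@H](CSc1ccccc1)Nc1ccc(S(=O)(=O)NC(=O)c2ccc(N3CCN(C(=O)Nc4ccccc4)CC3)cc2)cc1[N+](=O)[O-]` yields only a limit of this assay, > 50000 nM, which is the limit of > 50000 nM in this assay, at which 1 of the 3 values shown sits. Compound 3 `COc1ccccc1CN1CCN(c2ccc(C(=O)NS(=O)(=O)c3ccc(N[C@H](CCN(C)C)CSc4ccccc4)c([N+](=O)[O-])c3)cc2)CC1` gives 950 nM in this assay; this is the highest of the two numbers shown, compound 1 standing nearest with a lower value. Among the measured compounds shown here, the one measured step, an at least 52-fold lower number from compound 2 to compound 3 (1.72 log units; beyond the scatter), concerns a different part of the molecule. Compound 4 `CN(C)CC[C@H](CSc1ccccc1)Nc1ccc(S(=O)(=O)NC(=O)c2ccc(N3CCN(Cc4ccccc4C(F)(F)F)CC3)cc2)cc1[N+](=O)[O-]` differs from compound 3 by trifluoromethyl in place of methoxy on an aromatic carbon. For the measured compounds named here, no measured step bears on this change, so no step beyond the scatter is expected in this assay; the estimated step is a 1.3-fold higher number from compound 3 to compound 4 (0.10 log units; within the scatter). Compound 4 is expected to give 1200 nM, with a range from 300 nM to 5000 nM.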

Compound 4, half-maximal effective concentration: 130 nM
Compound 4: the middle estimate sits 9.2-fold (0.97 log units) above what was measured; measured number outside the range, below it.
By their numbers in this assay, from the lowest: compounds 4 and 1 (each within the scatter of the next); then compound 3. At a limit, above all of these: compound 2.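

In this assay the group on this aromatic carbon, ortho to a large group, is not interchangeable: trifluoromethyl in place of methoxy gives a 7.3-fold lower number from compound 3 to compound 4 (0.86 log units; beyond the scatter). With 2-(trifluoromethyl)benzyl on the amine nitrogen in the ring, the step away from phenylcarbamoyl is an at least 380-fold lower number from compound 2 to compound 4 (2.58 log units; beyond the scatter). That step starts from a limit for compound 2: the limit of > 50000 nM in this assay, at which 1 of the 4 values shown sits.

On these data alone, whether chlorine, a nitrile or a methyl group on this carbon would follow trifluoromethyl or methoxy stays open. Also open, as far as these compounds go, is whether trifluoromethyl in place of methoxy on the ring of compound 1 would give a similar step.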